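Chloro on the amide-side phenyl of compound 1

The compounds below may be only part of what the source reports. "The series", "measured", "known", "first", "only" and "open" are said of these compounds alone.

Three compounds on the shared core have numbers in a functional assay on Huh-7 cells (Homo sapiens) for inhibition, read by MTT assay, with a stated time of 48 h; a higher number here means a weaker inhibitor, a lower number a stronger inhibitor. Compound 1 `COc1ccc2c(=O)c(/C=C/C(=O)Nc3ccccc3)coc2c1` gives 9050 nM, the lowest of the three. Compound 2 `Cc1ccccc1NC(=O)/C=C/c1coc2cc(O)ccc2c1=O` gives 11100 nM, within the scatter of compound 1. Among the measured compounds shown here, compound 3 `COc1ccc2c(=O)c(/C=C/C(=O)NCc3ccc(F)cc3)coc2c1` gives 21000 nM; the step of a 2.3-fold higher number from compound 1 to compound 3 (0.37 log units; beyond the scatter) is the only single-point step among the measured compounds. Compound 4 `COc1ccc2c(=O)c(/C=C/C(=O)Nc3ccccc3Cl)coc2c1` differs from compound 1 by chloro in place of hydrogen on an aromatic carbon. The step from compound 1 to compound 3 alters the group on the amide-type nitrogen and bears on compound 4 only loosely; compound 2 carries a different ring substituent together with a change elsewhere, and its value shows only that such a pairing need not move the number far. For compound 4 the expected step is a 1.2-fold higher number from compound 1 to compound 4 (0.08 log units; within the scatter), within the scatter. Compound 4 is estimated at 11000 nM, with a range from 4500 nM to 26000 nM.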

Compound 4, half-maximal inhibitory concentration: 58400 nM
Compound 4: the middle estimate sits 5.3-fold (0.73 log units) below what was measured; measured number outside the range, above it.
By their numbers in this assay, from the lowest: compounds 1, 2 and 3 (each within the scatter of the next, the first and the last beyond it); then compound 4.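

Chloro in place of hydrogen on this aromatic carbon, ortho to a large group, is not a silent change: it gives a 6.5-fold higher number from compound 1 to compound 4 (0.81 log units; beyond the scatter) and so moves the number beyond the scatter. Set against the other amide-nitrogen group, 2-chlorophenyl also gives the higher number, with a 2.8-fold higher number from compound 3 to compound 4 (0.44 log units; beyond the scatter) on that comparison. Nothing measured here accounts for the loss.

Open, as far as these compounds go, is whether the loss follows chloro itself or this place on the ring. Fluoro, methyl or methoxy on this carbon, and an amine or a carboxylic acid on the phenyl, lie outside the compounds shown.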